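Ester Exchange on Compound 1 Leading to Compound 4

A few compounds are considered here, and "the series" means these few. Any claim that something is new, unique, unknown or untested is made for them only; others in the source may bear on it.

Measured compounds in a functional assay on the whole organism (strain Sprague-Dawley) for inhibition, with Rattus norvegicus as the target, with a stated time of 0.5 h, at a dose of 5 mg/kg by the oral route; on this read-out higher numbers stand for more inhibition at the one dose given (going by the name of the read-out) and lower numbers for less inhibition:
Compound 1 `CCCSc1nc(N[C@@H]2C[C@H]2c2ccc(F)c(F)c2)c2nnn([C@@H]3C[C@H](OC(C)=O)[C@@H](O)[C@H]3O)c2n1` gives "not determined" (no result reported).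
Compound 2 `CCCSc1nc(N[C@@H]2C[C@H]2c2ccc(F)c(F)c2)c2nnn([C@@H]3C[C@H](OC(=O)CC)[C@@H](O)[C@H]3O)c2n1` gives 44.5%.
Compound 3 `CCCSc1nc(N[C@@H]2C[C@H]2c2ccc(F)c(F)c2)c2nnn([C@@H]3C[C@H](OC(=O)CCC)[C@@H](O)[C@H]3O)c2n1` gives 28.5%.

Compound 1 therefore stands without a number in this assay, and nothing can be said of where it sits relative to compound 2 or compound 3. Compound 4 `CCCSc1nc(N[C@@H]2C[C@H]2c2ccc(F)c(F)c2)c2nnn([C@@H]3C[C@H](OCCOC(=O)c4cccnc4)[C@@H](O)[C@H]3O)c2n1` differs from compound 1 by 2-(((pyridin-3-yl)carbonyl)oxy)ethyl in place of acetyl on an oxygen on a saturated carbon. Within the data shown here, the one measured step, a number 16 percentage points lower from compound 2 to compound 3 (beyond the scatter), bears on compound 4 only loosely, as it concerns a single carbon added on the ester chain rather than the larger group entering here. That step was modest but beyond the scatter, in the direction of less inhibition as the ester grew. Compound 4 is therefore expected to show a modest read-out, estimated at 25% within a range of 5% to 50%.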

Compound 4, a percentage reported as inhibition, in the whole organism at one dose (the size of the read-out at that dose, not a potency): "not active" (no number reported)
For compound 4 the study gives words and no number, so the estimate cannot be set against anything.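

In this assay compound 4 gives "not active" (no number reported) and compound 1 gives "not determined" (no result reported) so no step can be read between compound 1 and compound 4. The compounds shown leave open how 2-(((pyridin-3-yl)carbonyl)oxy)ethyl compares with acetyl on this read-out. No evidence shown bears on the result for compound 4.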